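Pyridone chromenes on rat trachea: one untested step

This account rests on a few compounds, and the source may have more. Where it says the series, first, only, none or still open, it means among the compounds named here.

Measured compounds:
compound 1 `CCC(=O)c1ccc2c(c1)C(n1ccccc1=O)=CC(C)(C)O2` — 5.85
compound 2 `CC1(C)C=C(n2ccccc2=O)c2cc(OCC(=O)c3ccc(F)cc3)ccc2O1` — 4.77
compound 3 `CC1(C)C=C(n2ccccc2=O)c2cc(OC(=O)Nc3ccc(F)cc3)ccc2O1` — 4.37

The three compounds share one core and differ only in the group on the carbon-only aromatic ring. In a functional assay (trachea) with Rattus norvegicus as the target (a higher number here means a more potent compound, by a factor of ten per unit of this negative logarithm, a lower number a less potent compound), compound 1 gives 5.85, the highest of the three numbers; compound 2 stands lower and compound 3 lower still, both gaps beyond the scatter, so compound 1 is the most potent measured compound. Within the data shown here, the single comparison within the set, a number 0.40 log units lower from compound 2 to compound 3 (beyond the scatter), exchanges one group for another on an oxygen attached to the ring.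

Compound 4 `CC1(C)C=C(n2ccccc2=O)c2cc(-c3ccncc3)ccc2O1` derives from compound 1 by the change (pyridin-4-yl in place of propanoyl on an aromatic carbon). Among the measured compounds shown here, no measured step bears on this exchange: compounds 2 and 3 carry an oxygen-linked group, not a group bonded directly to the aromatic carbon, and their step concerns a different kind of substituent. For the measured compounds named here, the propanoyl compound 1 holds the highest number, and the series gives no analogue in which that group is replaced by a ring. The step is expected to be a number 0.55 log units lower from compound 1 to compound 4 (beyond the scatter), a modest drop, with wide uncertainty. For compound 4 the estimate in this assay is 5.3, ranging from 4.5 to 6.1.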

Compound 4, logarithm of the reciprocal of the active concentration, log(1/C): 6.32
The estimate for compound 4 lay 1.02 log units below the measured number; the measured number lies above the stated range.
By their numbers in this assay, from the lowest: compound 3; then compound 2; then compound 1; then compound 4.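

In this assay, a number 0.47 log units higher from compound 1 to compound 4 (beyond the scatter), so the propanoyl group is not needed for a high number at this aromatic carbon. Pyridin-4-yl, a six-membered aromatic ring with no carbonyl, can take its place on the shared core and compound 4 stands above compound 1. Compound 2 and compound 3 could not show this, as both carry their groups through an oxygen and neither has a ring bonded directly to the aromatic carbon. Nothing in the data shown accounts for the gain.

As far as these compounds go, whether the ring nitrogen of pyridin-4-yl contributes to the step remains open, and phenyl on the same carbon would test that directly. Also open, from the compounds shown here alone, is how a longer acyl chain such as butanoyl, or an amine, would compare with propanoyl at this position.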